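The source may report more compounds than this note shows. Statements on the series, on what has been measured and on what is new or still open speak of the compounds shown alone.

Measured so far:
Compound 1 `Cc1cc(Nc2cc(-c3ccccc3)[nH]n2)n2nc(SCc3ccc([N+](=O)[O-])cc3)nc2n1`, tested in a functional assay on PC-9 cells (Homo sapiens) for inhibition, read by MTT assay, with a stated time of 72 h (a lower number here means a stronger inhibitor, a higher number a weaker inhibitor), gives 7980 nM.
Compound 2 `Cc1cc(Nc2ccn(Cc3ccccc3)n2)n2nc(SCc3ccc(Br)cc3)nc2n1` reaches only a limit of the assay in this assay, > 50000 nM.
Compound 3 `CCCCCc1c(C)nc2nc(SCc3ccc(Cl)cc3)nn2c1Nc1cc(-c2ccccc2)[nH]n1` likewise reaches only a limit in this assay, > 50000 nM.

For the measured compounds named here, compound 1 therefore stands as the only compound with a definite number; the other two sit at the limit of > 50000 nM in this assay, at which 2 of the 3 values shown sit, so no step between measured compounds can be read off, and nothing tells how this series responds to a single change.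

Compound 4 `C=CCSc1nc2nc(C)cc(Nc3cc(-c4ccccc4)[nH]n3)n2n1` is the next compound to be tested. It differs from compound 1 in one place: vinyl in place of 4-nitrophenyl on a saturated chain carbon bound to a sulfur. The group that leaves carries a six-membered aromatic ring and two hydrogen-bond acceptors; the group that enters carries no ring and no acceptors. Going by the values given here, with no measured step to lean on, the expectation rests on this loss alone. The step of a 2.5-fold higher number from compound 1 to compound 4 (0.40 log units; beyond the scatter) is expected to run toward a weaker inhibitor and to lie beyond the usual scatter. Compound 4 is thus estimated at 20000 nM, within a range from 5000 nM to 50000 nM.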

Compound 4, half-maximal inhibitory concentration: > 50000 nM
Compound 4: no number, only a limit (the forecaster's own chance of this, stated with the estimate: 35%); middle value at least 2.5-fold (0.39 log units) from the limit.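

For the compounds shown here, this is the first step that can be read: in this assay, allyl in place of 4-nitrobenzyl on the sulfur gives an at least 6.2-fold higher number from compound 1 to compound 4 (0.79 log units; beyond the scatter). Compound 4 reaches only a limit of the assay, the same one that most of the compounds shown reach: the limit of > 50000 nM in this assay, at which 3 of the 4 values shown sit. The 4-nitrophenyl group at this place therefore cannot be swapped for the small vinyl group without a clear move toward weaker inhibition, and only the lower end of that move is known.

Compounds 2 and 3 differ from compound 1 in more than one place, so no further steps can be read. From the compounds shown here alone, whether the aromatic ring or its nitro group matters more stays open, and a plain benzyl, a 4-aminobenzyl or a longer chain such as hexyl on the same sulfur would bear on that.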